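This account rests on a few compounds, and the source may have more. Where it says the series, first, only, none or still open, it means among the compounds named here.

Measured so far:
Compound 1, `CNC(=O)c1ccccc1Oc1nc(Nc2ccccc2OC)ncc1Br`: > 50000 nM
Compound 2, `CNC(=O)c1ccccc1Oc1nc(Nc2ccc(C)cc2C)ncc1Br`: 40700 nM

Both compounds share one core and were tested in a functional assay on MDA-MB-468 cells (Homo sapiens) for antiproliferative activity, read by MTT assay, with a stated time of 24 h; on this read-out lower numbers stand for stronger inhibition and higher numbers for weaker inhibition. For compound 1 the result is a limit of the assay, > 50000 nM, and no number. Going by the values given here, compound 2 gives 40700 nM, the only number among the two results; the other result is the limit of > 50000 nM in this assay, at which 1 of the 2 values shown sits. Among the compounds with values here, the single measured step, an at least 1.2-fold lower number from compound 1 to compound 2 (0.08 log units; that floor lies within the scatter), changes the ring on the aromatic nitrogen and does not move the read-out beyond the scatter.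

Compound 3, `CNC(=O)c1ccccc1Oc1nc(Nc2cccc(OC)c2)ncc1Br`, differs from compound 2 as follows: 3-methoxyphenyl in place of 2,4-dimethylphenyl on a nitrogen on an aromatic ring. Within the data shown here, this change again exchanges the ring on the same nitrogen, so the step from compound 1 to compound 2 is the only guide, and that step stayed within the scatter. Compound 3 carries a methoxyphenyl, as compound 1 does, whose result was a limit. Compound 3 is therefore expected to stay close to compound 2, with the step of a 1.2-fold higher number from compound 2 to compound 3 (0.07 log units; within the scatter) expected to lie within the scatter. For compound 3 the expected value is 48000 nM, in the range 15000 nM to 160000 nM.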

Compound 3, half-maximal inhibitory concentration: 17800 nM
For compound 3 the middle estimate is 2.7-fold (0.43 log units) above the measured one; measured number inside the range.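

The ring on this nitrogen can move the read-out beyond the scatter, which the first step did not show: 3-methoxyphenyl in place of 2,4-dimethylphenyl gives a 2.3-fold lower number from compound 2 to compound 3 (0.36 log units; beyond the scatter). The two methoxyphenyl compounds differ only in how the ring carries that group, and 3-methoxyphenyl in place of 2-methoxyphenyl gives an at least 2.8-fold lower number from compound 1 to compound 3 (0.44 log units; beyond the scatter), so the mere presence of a methoxy group does not settle the result. That second step is only a floor, and its true size cannot be read, because compound 1 stands at a limit of the assay and not at a number: the limit of > 50000 nM in this assay, at which 1 of the 3 values shown sits.

The compounds shown leave open whether the oxygen of the 3-methoxyphenyl group matters at all, a question that a 3-methylphenyl or a 3-hydroxyphenyl group on the same nitrogen would address. They also leave open whether a longer chain on that oxygen, such as 3-ethoxyphenyl, or an amine on the ring would bring the number for compound 3, now 17800 nM, down further.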